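Bicyclic amides: changing the substituent on the cyclopropyl

The source may report more compounds than this note shows. Statements on the series, on what has been measured and on what is new or still open speak of the compounds shown alone.

Three amides on a shared bicyclic core have been measured so far. Compound 1 `CCC(=O)N1CC2CC(C1)N2` gives 98% in an assay on SH-EP1 cells for agonist activity at Neuronal acetylcholine receptor; alpha4/beta2 (Homo sapiens), read by FLIPR and calcium flux; a higher number here means a larger maximal response, a lower number a smaller maximal response. Compound 2 `CCCC(=O)N1CC2CC(C1)N2` gives 120%, and compound 3 `O=C([C@@H]1C[C@@H]1F)N1CC2CC(C1)N2` gives 120%. The step of a number 22 percentage points higher from compound 1 to compound 2 (beyond the scatter) and the step of a number 22 percentage points higher from compound 1 to compound 3 (beyond the scatter) are both modest gains beyond the scatter, whereas the step of no change at the digits printed from compound 2 to compound 3 (within the scatter) is flat. Among the compounds with values here, compound 3 thus stands level with compound 2 at the top of the three numbers, with compound 1 the only clearly lower value.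

Compound 4 `C[C@@H]1C[C@@H]1C(=O)N1CC2CC(C1)N2` is not yet measured. It differs from compound 3 as follows: a group of 4 heavy atoms (4 carbon; one three-membered non-aromatic ring of carbon only) in place of a group of 4 heavy atoms (3 carbon, 1 fluorine; one three-membered non-aromatic ring of carbon only), on a carbonyl carbon. The three-membered ring on the carbonyl carbon is kept in both. The closest guide is the step of no change at the digits printed from compound 2 to compound 3 (within the scatter), which shows that a chain and a substituted three-membered ring on the carbonyl carbon give the same maximal response, and the step of a number 22 percentage points higher from compound 1 to compound 3 (beyond the scatter) only marks the lowest value seen in the set. No change beyond the scatter is therefore expected in this assay for compound 4. The expected step is a number 5 percentage points lower from compound 3 to compound 4 (within the scatter). Compound 4 is estimated at 115%, with a range from 95% to 135%.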

Compound 4, largest response reached (Emax), in percent of the reference or control that the assay uses: 88%
Beside the measured number, compound 4's estimate is 27 percentage points above it; the measured number lies below the stated range.
By their numbers in this assay, from the lowest: compounds 4 and 1 (each within the scatter of the next); then compounds 2 and 3 (each within the scatter of the next).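

On the carbonyl carbon, keeping the three-membered ring does not by itself keep the maximal response in this assay (a number 32 percentage points lower from compound 3 to compound 4 (beyond the scatter)), so the group carried on that ring matters, which compounds 1 to 3 could not show. The open propyl chain gives the same gap (a number 32 percentage points lower from compound 2 to compound 4 (beyond the scatter)), whereas the ethyl group does not separate from the new ring (a number 10 percentage points lower from compound 1 to compound 4 (within the scatter)), so a ring-bearing amide can fall at either end of the values seen so far. Nothing available here accounts for the difference between the fluorine and carbon substituents on the ring.

Still open, going by these compounds, is whether unsubstituted cyclopropyl, or a ring bearing chlorine, hydroxyl or trifluoromethyl, would sit with compound 3 or with compound 4. The compounds shown also leave open how the other stereoisomers of either ring would respond.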